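The compounds below may be only part of what the source reports. "The series", "measured", "known", "first", "only" and "open" are said of these compounds alone.

Measured in a functional assay on MCF7 cells (Homo sapiens) for antiproliferative activity, read by MTT assay, with a stated time of 48 h; a lower number here means a stronger inhibitor, a higher number a weaker inhibitor:
compound 1 `COc1ccc(C2OC(c3ccc4ccccc4c3)=NN2C(C)=O)cc1`: 7.35 ug/mL
compound 2 `CC(=O)N1N=C(c2ccc3ccccc3c2)OC1c1ccc(Cl)cc1`: 2.63 ug/mL

Of these two, compound 2 stands lower, at 2.63 ug/mL, and is the stronger inhibitor in this assay. Among the measured compounds shown here, compound 1 is the only neighbour it can be compared with. For the measured compounds named here, the one measured step is a 2.8-fold lower number from compound 1 to compound 2 (0.45 log units; beyond the scatter), and it comes from chloro in place of methoxy on an aromatic carbon.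

The next compound is compound 3 `CC(=O)N1N=C(c2ccc3ccccc3c2)OC1c1ccc(F)cc1`. It differs from compound 2 by fluoro in place of chloro on an aromatic carbon, which is fluoro in place of chloro on an aromatic carbon, at the same place, para to a large group. Going by the values given here, no measured step covers this exchange directly. Among the compounds with values here, the only guide is the modest step of a 2.8-fold lower number from compound 1 to compound 2 (0.45 log units; beyond the scatter), which shows that a change at this place can move the number beyond the scatter. A step of similar or smaller size is therefore expected in this assay, more likely towards a higher number, though the direction is uncertain. The expected change is a 1.5-fold higher number from compound 2 to compound 3 (0.18 log units; within the scatter). For compound 3 the estimated value is 4 ug/mL, with an expected range from 1.7 ug/mL to 9 ug/mL.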

Compound 3, half-maximal inhibitory concentration: 3.02 ug/mL
The estimate for compound 3 lay 1.3-fold (0.12 log units) above the measured number; the measured number falls inside the stated range.
By their numbers in this assay, from the lowest: compounds 2 and 3 (each within the scatter of the next); then compound 1.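

In this assay, the exchange of 4-chlorophenyl for 4-fluorophenyl gives a 1.1-fold higher number from compound 2 to compound 3 (0.06 log units; within the scatter), so at this place, on an aromatic carbon para to a large group, the chloro and fluoro compounds cannot be told apart. The step of a 2.4-fold lower number from compound 1 to compound 3 (0.39 log units; beyond the scatter) shows that the move away from methoxy seen in a 2.8-fold lower number from compound 1 to compound 2 (0.45 log units; beyond the scatter) is not particular to chloro, since fluoro in place of methoxy also carries the number beyond the scatter. No supporting data bear on why the two halogen compounds read alike or why both part from the methoxy compound.

With only methoxy, chloro and fluoro shown at this place, it stays open how an amine, a carboxylic acid, a longer alkyl chain or a plain hydrogen would read there, and so whether the lower numbers belong to halogens as a class or extend to other groups. It also stays open whether the same relation among these three groups would hold on a different core or in a different cell line.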